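The source may hold more compounds than are shown below. What is called first, only, known or untested is meant among the compounds shown, and "the series" means these compounds.

In a functional assay on PC-3 cells (Homo sapiens) for antiproliferative activity, read by MTT assay, with a stated time of 24 h (a higher number here means a weaker inhibitor, a lower number a stronger inhibitor), compound 1 (`CCn1c(C(=O)N[C@@H](CC(=O)OC)C(=O)OC)ccc1C(CC)(CC)c1ccc(OCS(=O)(=O)c2ccccc2)c(C)c1`) gives 6490 nM while compound 2 (`CCN(CC)CCNC(=O)c1ccc(C(CC)(CC)c2ccc(OCS(=O)(=O)c3ccccc3)c(C)c2)n1CC`) gives 7130 nM and compound 3 (`CCn1c(C(=O)NC(C)(C)CO)ccc1C(CC)(CC)c1ccc(OCS(=O)(=O)c2ccccc2)c(C)c1`) gives 9850 nM as its result. These three numbers lie within the usual scatter of one another, so compound 2 cannot be ranked against either of the others. All three carry the phenylsulfonyl group and differ in the group on an amide-type nitrogen. The measured steps are a 1.1-fold higher number from compound 1 to compound 2 (0.04 log units; within the scatter) and a 1.5-fold higher number from compound 1 to compound 3 (0.18 log units; within the scatter) and also a 1.4-fold higher number from compound 2 to compound 3 (0.14 log units; within the scatter) in the same read-out.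

Compound 4 (`CCN(CC)CCNC(=O)c1ccc(C(CC)(CC)c2ccc(OCSC)c(C)c2)n1CC`) departs from compound 2 in one place (methylsulfanyl in place of phenylsulfonyl on a saturated chain carbon bound to an oxygen on an aromatic ring) and is otherwise the same: methylsulfanyl stands in place of phenylsulfonyl on a saturated chain carbon bound to an oxygen on an aromatic ring. Going by the values given here, none of the measured steps touches that place, so they bear on this change only indirectly and the data hold no direct precedent for it. Among the compounds with values here, they show only that three different amide groups leave the numbers inseparable. No step beyond the scatter is therefore expected in this assay, although this expectation is weakly grounded and a larger step in either direction remains possible. The expected step is a 1.3-fold higher number from compound 2 to compound 4 (0.10 log units; within the scatter) on this estimate. For compound 4 the estimated value is 9000 nM with an expected range from 3500 nM to 25000 nM in this test.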

Compound 4, half-maximal inhibitory concentration: 4010 nM
Compound 4: the middle estimate sits 2.2-fold (0.35 log units) above what was measured; measured number inside the range.
By their numbers in this assay, from the lowest: compounds 4, 1, 2 and 3 (each within the scatter of the next, the first and the last beyond it).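

In this assay the change to this place, a saturated chain carbon bound to an oxygen on an aromatic ring, gives a 1.8-fold lower number from compound 2 to compound 4 (0.25 log units; within the scatter) and this step lies within the scatter. Going by these compounds alone, the earlier compounds varied only the group on an amide-type nitrogen, so this pair is the first look at the other end of the molecule: phenylsulfonyl, with 9 heavy atoms and a six-membered aromatic ring, gives way to methylsulfanyl, with 2 heavy atoms and no ring, and the number does not separate from that of compound 2. Nothing measured here bears on why the two numbers stay so close.

This swap changes the ring and the two sulfonyl oxygens at once, so the compounds shown cannot separate the two, and methylsulfonyl or phenylsulfanyl at this place would pull them apart. They also leave open whether the same swap behaves alike with the 1-(hydroxymethyl)-1-methylethyl or 1,2-bis(methoxycarbonyl)ethyl groups on the amide-type nitrogen, and what a longer chain on the sulfur would do.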